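This account rests on a few compounds, and the source may have more. Where it says the series, first, only, none or still open, it means among the compounds named here.

Measured so far in a functional assay on the whole organism with Rattus norvegicus as the target, read by paw edema, with a stated time of 3 h, at a dose of 100 mg/kg by the oral route; a higher number here means more inhibition at the dose given (going by the name of the read-out), a lower number less inhibition:

- compound 1 `CCc1cccc(-c2nc3cc(Cl)ccc3[nH]2)n1`: 3%
- compound 2 `Cc1ccc(-c2nc3ccccc3n2CC(=O)N2CCN(C)CC2)nc1`: 11%
- compound 3 `CCc1ccc(-c2nc3ccccc3n2C)nc1`: 5%

All three numbers are small, and every gap between them lies within the scatter of this assay. Compound 3 stands second highest of the three numbers as written, but its gap to compound 1 and its gap to compound 2 both lie within the scatter, so no order among the three can be read from these figures.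

The next compound, compound 4 `CCc1ccc(-c2nc3ccccc3n2CC(=O)OC)nc1`, differs from compound 3 in one place: methoxycarbonyl in place of hydrogen on a saturated chain carbon bound to an aromatic nitrogen. Within the data shown here, no step between measured compounds has been worked out, so the size of this step must be judged from the values themselves. Compound 2 carries a larger substituent on the same chain carbon and gives 11%, while compound 3 with the bare methyl gives 5%; these two numbers are within the scatter of each other, so the substituent at this carbon has so far made no difference beyond the noise. The step from compound 3 to compound 4 is therefore expected to be none beyond the scatter, a number 1 percentage points higher from compound 3 to compound 4 (within the scatter), because compound 2 with 11% and compound 3 with 5% show no separation. Compound 4 is thus estimated at 6%, within 0% to 18%.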

Compound 4, a percentage reported as inhibition, in the whole organism at one dose (the size of the read-out at that dose, not a potency): 9%
Compound 4: middle estimate off by 3 percentage points, on the low side; the range from low to high includes it.
By their numbers in this assay, from the lowest: compounds 1, 3, 4 and 2 (each within the scatter of the next).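

In this assay, among these compounds, the change from methyl to (methoxycarbonyl)methyl gives a number 4 percentage points higher from compound 3 to compound 4 (within the scatter) and is the first step that can be read between compounds differing in one place. At the saturated chain carbon bound to an aromatic nitrogen, adding methoxycarbonyl, with its 4 heavy atoms, 2 hydrogen-bond acceptors and no net charge, therefore leaves the read-out indistinguishable from that of the compound with hydrogen at this place. No measurement is available that could explain this result or connect it to any property of the group.

Among the compounds shown here, it remains open whether any replacement at this chain carbon can separate from hydrogen in this assay by more than the scatter, since this single step tests only one group at one dose and one stated time. A carboxylic acid in place of the methoxycarbonyl, a simple amine on the same carbon or a longer chain ending in methoxycarbonyl would each put this question in one place on the core of compound 3.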